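Fluoro in place of methyl: working notes on compound 3

A few compounds are considered here, and "the series" means these few. Any claim that something is new, unique, unknown or untested is made for them only; others in the source may bear on it.

Measured so far in an ADME assay on HeLa cells (Homo sapiens) for cytotoxicity, read by crystal violet staining, with a stated time of 72 h (a higher number here means that more compound is tolerated, a lower number that less compound is tolerated), are two compounds
compound 1 `COC(=O)c1cc(CCCOc2c(C)cc(-c3noc(C(F)(F)F)n3)cc2C)on1` gives (35400 nM)
compound 2 `CCOC(=O)c1cc(CCCOc2ccc(-c3noc(C(F)(F)F)n3)cc2C)on1` gives (35100 nM)

Going by the values given here, compound 2 (35100 nM) and compound 1 (35400 nM) lie within the scatter of each other, so the series so far sits at a single level. Among the compounds with values here, the two structures differ in more than one place, and no measured step isolates a single change.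

Compound 3 `CCOC(=O)c1cc(CCCOc2ccc(-c3noc(C(F)(F)F)n3)cc2F)on1` is compound 2 with one change (fluoro in place of methyl on an aromatic carbon): fluoro in place of methyl on an aromatic carbon, ortho to a large group and meta to a 5-(trifluoromethyl)-1,2,4-oxadiazol-3-yl group. The data hold no direct measure of this change in this assay. The expectation is no step beyond the scatter, in either direction. It rests on compound 2 (35100 nM) and compound 1 (35400 nM), which stay within the scatter of each other despite their structural differences. The estimated change is small (a 1.1-fold lower number from compound 2 to compound 3 (0.03 log units; within the scatter)). Compound 3 is expected at 33000 nM (estimated range 15000 nM to 70000 nM).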

Compound 3, half-maximal cytotoxic concentration: 60200 nM
Compound 3: middle estimate off by 1.8-fold (0.26 log units), on the low side, within the range that was stated.
By their numbers in this assay, from the lowest: compounds 2, 1 and 3 (each within the scatter of the next).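

With a 1.7-fold higher number from compound 2 to compound 3 (0.23 log units; within the scatter), the series has its first comparison in this assay that isolates a single change: fluoro in place of methyl on an aromatic carbon, ortho to a large group and meta to a 5-(trifluoromethyl)-1,2,4-oxadiazol-3-yl group. For this one pair, the exchange of one heavy atom for another leaves compound 2 and compound 3 at a single level, so the flat picture seen earlier now also holds across a defined change at a known place, and not only across compounds that differ in several places. Nothing measured here bears on why the step has this size.

The compounds shown carry only methyl or fluoro at this place, so whether an amine, a methoxy group or a longer chain there would stay at the same level remains open. Going by these compounds alone, the ester end is also unresolved, as compound 1 and compound 2 differ in more than one place, and a carboxylic acid or an amide in place of the ester would address a part of the structure that no single step here covers.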